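A few compounds are considered here, and "the series" means these few. Any claim that something is new, unique, unknown or untested is made for them only; others in the source may bear on it.

Series notes on the shared core of compound 1 `COc1ccc(/C=N/NC(=O)Nc2ccc(Oc3ccnc(-c4nncn4CCN(C)C)c3)c(F)c2)c(OC)c1OC`.

In an ADME assay on WI-38 cells (Homo sapiens) for cytotoxicity, read by MTT assay, with a stated time of 72 h (on this read-out higher numbers stand for weaker inhibition and lower numbers for stronger inhibition), compound 1 has no result reported, so it stands as "not determined" (no result reported) on this read-out. Among the compounds with values here, compound 2 `CN(C)CCn1cnnc1-c1cc(Oc2ccc(NC(=O)N/N=C/c3ccc(F)cc3F)cc2F)ccn1` is the one member with a figure: in this assay compound 2 gives 5030 nM. Compound 3 `CN(C)CCn1cnnc1-c1cc(Oc2ccc(NC(=O)N/N=C/c3ccc(O)c(O)c3)cc2F)ccn1` likewise has no result reported in this assay, where compound 3 stands as "not determined" (no result reported). Within the data shown here, with a single number in hand, no step between measured compounds can be drawn, and nothing about direction is known.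

Compound 4 `Cc1cc(/C=N/NC(=O)Nc2ccc(Oc3ccnc(-c4nncn4CCN(C)C)c3)c(F)c2)cc(C)c1O` differs from compound 1 in one place: 4-hydroxy-3,5-dimethylphenyl in place of 2,3,4-trimethoxyphenyl on a carbon with a double bond to nitrogen. Whether this change moves this assay at all cannot be read from the data; compound 1 has no value to move from. Among the measured compounds shown here, the working expectation is no step beyond the scatter, with the only anchor being compound 2 in this assay.

For compound 4 in this assay the estimate is 5000 nM, expected to fall between 1500 nM and 20000 nM.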

Compound 4, half-maximal inhibitory concentration: 3610 nM
The estimate for compound 4 lay 1.4-fold (0.14 log units) above the measured number; measured number inside the range.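

Compound 4 gives the series its first readable step in this assay: 4-hydroxy-3,5-dimethylphenyl in place of 2,4-difluorophenyl on a carbon with a double bond to nitrogen gives a 1.4-fold lower number from compound 2 to compound 4 (0.14 log units; within the scatter) on this read-out. This exchange of one substituted phenyl for another, with fluorine replaced by hydroxy and methyl groups, therefore shows no change beyond the scatter. Steps involving compound 1 or compound 3 cannot be read, and no measurement bearing on a cause is at hand.

Still open, on these data alone, is whether a carboxylic acid or an amine on the phenyl at this place would shift the number beyond the scatter. Also open, as far as these compounds go, is how the hydroxy and methyl groups of the 4-hydroxy-3,5-dimethylphenyl group each count on their own.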